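Chlorophenyl placement on the amide-type nitrogen: compound 4

The source may report more compounds than this note shows. Statements on the series, on what has been measured and on what is new or still open speak of the compounds shown alone.

Measured compounds in a functional assay on the whole organism (strain Swiss albino) with Mus musculus as the target, in the maximal electroshock model, with a stated time of 4 h; on this read-out lower numbers stand for an effect already at smaller amounts and higher numbers for an effect only at larger amounts of compound:
- compound 1, `COc1cc2c(cc1OC)C(=O)C(CC1CCN(C(=S)Nc3ccccc3[N+](=O)[O-])CC1)C2`: 300 mg/kg
- compound 2, `COc1cc2c(cc1OC)C(=O)C(CC1CCN(C(=S)Nc3ccc([N+](=O)[O-])cc3)CC1)C2`: 300 mg/kg
- compound 3, `COc1cc2c(cc1OC)C(=O)C(CC1CCN(C(=S)Nc3ccccc3Cl)CC1)C2`: 300 mg/kg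

Compound 3 stands level with compounds 1 and 2 at the digits shown; its nearest neighbour is compound 1 and its furthest is compound 2, both within the scatter. Among the compounds with values here, every step so far has been flat: no change at the digits printed from compound 1 to compound 2 (within the scatter), no change at the digits printed from compound 1 to compound 3 (within the scatter), no change at the digits printed from compound 2 to compound 3 (within the scatter).

Compound 4, `COc1cc2c(cc1OC)C(=O)C(CC1CCN(C(=S)Nc3ccc(Cl)cc3)CC1)C2`, is the next case. The change is 4-chlorophenyl in place of 2-chlorophenyl on an amide-type nitrogen. Within the data shown here, the step that bears on it most directly is the one from compound 1 to compound 2, where the same kind of move of a substituent around the phenyl on the amide-type nitrogen gave no change at the digits printed from compound 1 to compound 2 (within the scatter). The exchange of nitro for chloro from compound 1 to compound 3 was likewise flat. Nothing in the series has yet moved this assay beyond the scatter, so for compound 4 the expected step is no change at the digits printed from compound 3 to compound 4 (within the scatter), none beyond the scatter in either direction. Compound 4 is therefore estimated at 300 mg/kg, with a range from 150 mg/kg to 600 mg/kg.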

Compound 4, minimum effective dose: 100 mg/kg
For compound 4 the middle estimate is 3.0-fold (0.48 log units) above the measured one, and the stated range ends above it.
By their numbers in this assay, from the lowest: compound 4; then compounds 1, 2 and 3 (each within the scatter of the next).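

In this assay, within the data shown here, 4-chlorophenyl in place of 2-chlorophenyl on the amide-type nitrogen gives a 3.0-fold lower number from compound 3 to compound 4 (0.48 log units; beyond the scatter), the first change to move this read-out, whereas the corresponding change with nitro gave no change at the digits printed from compound 1 to compound 2 (within the scatter). With the substituent's place on the phenyl held fixed, chloro in place of nitro now gives a 3.0-fold lower number from compound 2 to compound 4 (0.48 log units; beyond the scatter), and the cross-comparison with 2-nitrophenyl gives a 3.0-fold lower number from compound 1 to compound 4 (0.48 log units; beyond the scatter). The effect of exchanging nitro for chloro therefore depends on where the group sits on the phenyl: the same change on two cores in this assay, no change at the digits printed (within the scatter) from compound 1 to compound 3 and a 3.0-fold lower number (0.48 log units; beyond the scatter) from compound 2 to compound 4, 3.0-fold (0.48 log units) apart, beyond the scatter of two such steps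

Going by these compounds, whether 4-bromophenyl or 4-methoxyphenyl on the amide-type nitrogen would match 4-chlorophenyl remains open. Also open, on these data alone, is whether the step would persist with a carbonyl in place of the thiocarbonyl.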